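Fluorine removal on the benzylamide of compound 1

This account rests on a few compounds, and the source may have more. Where it says the series, first, only, none or still open, it means among the compounds named here.

Compound 1 `COc1ccc(CNC(=O)c2nc(-c3ccc(F)cc3)n(CC[C@@H](O)C[C@@H](O)CC(=O)O)c2C2CC2)cc1F` and compound 2 `Cc1ccc(CNC(=O)c2nn(-c3ccc(F)cc3)c(CC[C@@H](O)C[C@@H](O)CC(=O)O)c2C(C)C)cc1` have been run in an assay on microsomes from liver for inhibition of 3-hydroxy-3-methylglutaryl-coenzyme A reductase (Rattus norvegicus), read by scintillation counting, with stated times of 0.5 h and 0.75 h; on this read-out lower numbers stand for stronger inhibition and higher numbers for weaker inhibition. Compound 1 gives 3.7 nM, the higher of the two numbers; compound 2 gives 1 nM, a gap beyond the scatter. Compound 3 `COc1cccc(CNC(=O)c2nc(-c3ccc(F)cc3)n(CC[C@@H](O)C[C@@H](O)CC(=O)O)c2C2CC2)c1` is not yet measured. It differs from compound 1 in one place: 3-methoxyphenyl in place of 3-fluoro-4-methoxyphenyl on a saturated chain carbon bound to an amide-type nitrogen. Going by the values given here, no measured pair shows this change, so its size is open. The step expected in this assay is a 1.4-fold higher number from compound 1 to compound 3 (0.13 log units; within the scatter), within the scatter or a little toward weaker inhibition. Compound 3 is expected at 5 nM, with a range from 2 nM to 12 nM.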

Compound 3, half-maximal inhibitory concentration: 1.2 nM
Compound 3: middle estimate off by 4.2-fold (0.62 log units), on the high side, outside the stated range (below it).
By their numbers in this assay, from the lowest: compounds 2 and 3 (each within the scatter of the next); then compound 1.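

In this assay, this aryl group on a saturated chain carbon bound to an amide-type nitrogen is sensitive to substitution: 3-methoxyphenyl in place of 3-fluoro-4-methoxyphenyl gives a 3.1-fold lower number from compound 1 to compound 3 (0.49 log units; beyond the scatter). The fluorine is lost and the methoxy is at 3 rather than 4, so this single step cannot separate the two changes. No measurement here offers an explanation for the step.

On these data alone, the separate contributions remain open, and 4-methoxyphenyl would isolate the fluorine's part. As far as these compounds go, whether 3-ethoxyphenyl or 3-aminophenyl is tolerated also remains open.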